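The compounds below may be only part of what the source reports. "The series", "measured", "known", "first", "only" and "open" are said of these compounds alone.

Measured in an assay on isolated protein for inhibition of ubiquitin carboxyl-terminal hydrolase 7 (Homo sapiens), with stated times of 30 min and 2 h; a higher number here means a weaker inhibitor, a lower number a stronger inhibitor:
compound 1 `Cn1nc2c(=O)n(CC3(O)CCN(Cc4ccc(-c5ccco5)cc4Cl)CC3)cnc2c1-c1ccc(CO)cc1` gives 42.5 nM
compound 2 `Cn1nc2c(=O)n(CC3(O)CCN(Cc4ccc(-c5ccoc5)cc4Cl)CC3)cnc2c1-c1ccc(CN)cc1` gives 177 nM
compound 3 `CC(=O)NCc1ccc(-c2c3ncn(CC4(O)CCN(Cc5ccc(-c6ccco6)cc5Cl)CC4)c(=O)c3nn2C)cc1` gives 46.1 nM

Compound 2 gives the highest number of the three, and its gaps to compound 3 and to compound 1 are both beyond the scatter, so it is the weakest inhibitor of this set in this assay. Compound 4 `Cn1nc2c(=O)n(CC3(O)CCN(Cc4ccc(C5=CCCC5)cc4Cl)CC3)cnc2c1-c1ccc(CN)cc1` differs from compound 2 in one place: cyclopent-1-en-1-yl in place of furan-3-yl on an aromatic carbon. For the measured compounds named here, the only measured step, a 1.1-fold higher number from compound 1 to compound 3 (0.04 log units; within the scatter), changes a different group and does not touch the one exchanged here, so it gives no direct guide; compounds 1 and 2 differ in two places at once, and their two values alone cannot be split between those places. Going by the values given here, with no step bearing on this exchange, the expectation is no change beyond the scatter, a 1.1-fold higher number from compound 2 to compound 4 (0.05 log units; within the scatter). Compound 4 is estimated at 200 nM, with a range of 70 nM to 600 nM.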

Compound 4, half-maximal inhibitory concentration: 76.9 nM
For compound 4 the middle estimate is 2.6-fold (0.42 log units) above the measured one, within the range that was stated.
By their numbers in this assay, from the lowest: compounds 1, 3 and 4 (each within the scatter of the next); then compound 2.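

In this assay, this aromatic carbon para to a large group responds to the exchange of furan-3-yl for cyclopent-1-en-1-yl, with a 2.3-fold lower number from compound 2 to compound 4 (0.36 log units; beyond the scatter). In this pair, the ring oxygen and the aromaticity of the five-membered ring are not required to keep the inhibition, and losing them goes with a lower number. Nothing at hand accounts for the size of this step. Open, from the compounds shown here alone, is how a saturated cyclopentyl or a phenyl group would read at this position. Furan-2-yl and furan-3-yl also remain unseparated, compound 1 and compound 2 differing in two places.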